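The source may hold more compounds than are shown below. What is called first, only, known or untested is meant among the compounds shown, and "the series" means these compounds.

Of the compounds shown here, three have so far been measured in a functional assay on LOX IMVI cells (Homo sapiens) for cytotoxicity, read by sulforhodamine B assay, with a stated time of 48 h; on this read-out lower numbers stand for stronger inhibition of growth and higher numbers for weaker inhibition of growth. Compound 1 `ClCc1ccccc1Cn1cnc2c(Cl)nc(Cl)nc21` gives 150 nM. Compound 2 `ClCc1ccccc1Cn1cnc2c(Cl)ncnc21` differs from compound 1 in one place; in this assay compound 2 gives 2130 nM. Compound 3 `ClCc1ccccc1Cn1cnc2ncnc(Cl)c21` gives 1340 nM.

The change from compound 2 to compound 1 is chloro in place of hydrogen on an aromatic carbon, and it produced a 14-fold lower number from compound 2 to compound 1 (1.15 log units; beyond the scatter). Compound 2 and compound 3 are built from the same atoms joined differently; the difference between the two cores is not broken down here. The values of compound 2 and compound 3 lie within the usual scatter of each other, so nothing can be read from the gap between them.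

Compound 4 `ClCc1ccccc1Cn1cnc2nc(Cl)nc(Cl)c21` has not yet been measured. It arises from compound 3 by chloro in place of hydrogen on an aromatic carbon. The surroundings of the new chloro are described in exactly the same words as in the earlier pair, so this is the same change, made for a second time on the other core. For the measured compounds named here, the expected step is an 8.9-fold lower number from compound 3 to compound 4 (0.95 log units; beyond the scatter), which rests on the single earlier example and on the assumption that the core difference, which is not broken down, does not alter its effect. Compound 4 is therefore expected to give about 150 nM, most likely somewhere from 50 nM to 500 nM, because the earlier step of the same kind was a 14-fold lower number from compound 2 to compound 1 (1.15 log units; beyond the scatter).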

Compound 4, concentration for 50% growth inhibition: 160 nM
The estimate for compound 4 lay 1.1-fold (0.03 log units) below the measured number; the measured number falls inside the stated range.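

In this assay, chloro in place of hydrogen on the aromatic carbon between two ring nitrogen atoms gave an 8.4-fold lower number from compound 3 to compound 4 (0.92 log units; beyond the scatter). Set beside the earlier step, the same change gave steps on the two cores that cannot be told apart: the same change on two cores in this assay, a 14-fold lower number (1.15 log units; beyond the scatter) from compound 2 to compound 1 and an 8.4-fold lower number (0.92 log units; beyond the scatter) from compound 3 to compound 4, 1.7-fold (0.23 log units) apart, within the scatter of two such steps. This shows that, for these two pairs, the change carried over from one core to the other in direction and, as far as the scatter allows one to say, in size; it does not show why chloro has this effect, nor whether the step would hold on a further core or in a different kind of assay.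

At this position the compounds shown carry only hydrogen or chloro, so it remains open whether another group, such as an amine, a methoxy group or a longer carbon chain, would produce a step of similar size on either core. Also open, going by these compounds, is what the chloromethyl group contributes to these numbers, and whether the step would survive a change to it, since that group stands unchanged in all four compounds.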